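Sulfate on the sugar's primary hydroxyl of an oleyl glycoside

A few compounds are considered here, and "the series" means these few. Any claim that something is new, unique, unknown or untested is made for them only; others in the source may bear on it.

Measured so far:
Compound 1, `CCCCCCCC/C=C\CCCCCCCCO[C@H]1O[C@H](CO)[C@@H](O)[C@H](O)[C@H]1NC(C)=O`: 4.6 uM
Compound 2, `CCCCCCCC/C=C\CCCCCCCCO[C@H]1O[C@H](CO)[C@@H](O)[C@H](OS(=O)(=O)O)[C@H]1NC(C)=O`: 9.6 uM

Within the data shown here, in a functional assay on U-373MG ATCC cells (Homo sapiens), read by thymidine incorporation (on this read-out lower numbers stand for stronger inhibition and higher numbers for weaker inhibition), compound 1 gives 4.6 uM and stands at the lowest of the two numbers known here. Compound 2 carries a sulfo group in place of hydrogen on a ring hydroxyl and shows a 2.1-fold higher number from compound 1 to compound 2 (0.32 log units; beyond the scatter), a modest weakening.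

Compound 3, `CCCCCCCC/C=C\CCCCCCCCO[C@H]1O[C@H](COS(=O)(=O)O)[C@@H](O)[C@H](O)[C@H]1NC(C)=O`, has not been measured. It differs from compound 1 by sulfo in place of hydrogen on an oxygen on a saturated carbon. Among the measured compounds shown here, the only measured step that bears on this is the one from compound 1 to compound 2, where the same kind of sulfo-for-hydrogen exchange sat on a different hydroxyl and moved the number only modestly upward. A step of similar size and direction is therefore expected here, so compound 3 is estimated at 8 uM, within 4 uM to 16 uM, which would mean a 1.7-fold higher number from compound 1 to compound 3 (0.24 log units; within the scatter).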

Compound 3, concentration for 50% inhibition: 13 uM
Beside the measured number, compound 3's estimate is 1.6-fold (0.21 log units) below it; measured number inside the range.
By their numbers in this assay, from the lowest: compound 1; then compounds 2 and 3 (each within the scatter of the next).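

In this assay, changing hydroxymethyl to (sulfooxy)methyl gives a 2.8-fold higher number from compound 1 to compound 3 (0.45 log units; beyond the scatter), so this position also loses some activity on taking the sulfo group, though the step is modest. With compound 2 at 9.6 uM and compound 3 at 13 uM, the two values lie within the scatter of each other, so these numbers do not separate one sulfated hydroxyl from the other, and the same exchange raises the number at both places tried. Nothing here shows what lies behind that rise.

Going by these compounds, it remains open whether a phosphate on the same oxygen, or a carboxylic acid in place of the hydroxymethyl, would give a similar number. Also open, on these data alone, is what a sulfo group on both of these hydroxyls together would do.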